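Styryl to Methoxynaphthyl: an Expected Antiproliferative Read-out

A few compounds are considered here, and "the series" means these few. Any claim that something is new, unique, unknown or untested is made for them only; others in the source may bear on it.

Measured compounds:
compound 1 `N#CC1=C(N)N(c2ccc(S(N)(=O)=O)cc2)C2=C(C(=O)CCC2)C1c1ccccc1`: 40%
compound 2 `N#CC1=C(N)N(c2ccc(S(N)(=O)=O)cc2)C2=C(C(=O)CCC2)C1/C=C/c1ccccc1`: 40%
compound 3 `N#CC1=C(N)N(c2ccc(S(N)(=O)=O)cc2)C2=C(C(=O)CCC2)C1c1cccc([N+](=O)[O-])c1`: 73%

The three measured compounds share one core and differ only in the group on a saturated ring carbon. In a functional assay on Ehrlich cells (Mus musculus) for antiproliferative activity, read by trypan blue exclusion, with a stated time of 2 h, tested at 50 ug/mL (on this read-out lower numbers stand for a weaker effect and higher numbers for a stronger effect at the one concentration tested), compound 2 stands level with compound 1 at the digits shown, the two together the lowest of the three numbers. Its nearest neighbour is compound 1, with no change at the digits printed from compound 1 to compound 2 (within the scatter), and its furthest is compound 3, with a number 33 percentage points higher from compound 2 to compound 3 (beyond the scatter). The step of a number 33 percentage points higher from compound 1 to compound 3 (beyond the scatter) points the same way.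

Compound 4 `COc1ccc2ccccc2c1C1C(C#N)=C(N)N(c2ccc(S(N)(=O)=O)cc2)C2=C1C(=O)CCC2` differs from compound 2 in one place: 2-methoxynaphthalen-1-yl in place of 2-phenylethenyl on a saturated ring carbon. Among the measured compounds shown here, two measured steps bear on this. The step from compound 1 to compound 2 shows that phenyl and 2-phenylethenyl give the same number, so an aromatic group on that carbon in itself leaves the read-out where it is. For the measured compounds named here, the large rise to compound 3 is tied to a nitro group, which compound 4 does not carry; no measured compound has a second fused aromatic ring or a methoxy group there, so that part of the change is uncovered by the data.

Compound 4 is therefore expected to give about 48%, between 30% and 68%. That amounts to an expected step of a number 8 percentage points higher from compound 2 to compound 4 (within the scatter), not clearly beyond the scatter.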

Compound 4, a percentage reported as activity, at one concentration (the size of the read-out at that concentration, not a potency): 70%
Estimate against measurement, compound 4: 22 percentage points below, and the stated range ends below it.
By their numbers in this assay, from the lowest: compounds 1 and 2 (each within the scatter of the next); then compounds 4 and 3 (each within the scatter of the next).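

In this assay, 2-methoxynaphthalen-1-yl in place of 2-phenylethenyl gives a number 30 percentage points higher from compound 2 to compound 4 (beyond the scatter), and in place of phenyl it gives a number 30 percentage points higher from compound 1 to compound 4 (beyond the scatter), which shows that this saturated ring carbon can carry a clearly higher read-out without any nitro group. Set against 3-nitrophenyl, the same group gives a number 3 percentage points lower from compound 3 to compound 4 (within the scatter), so the two substituents cannot be told apart in this assay, although they share neither a nitro group nor a methoxy group. Nothing available explains why the read-out rises with this change.

The change from compound 2 to compound 4 removes a double bond outside aromatic rings, adds a second six-membered aromatic ring and brings in a methoxy group all at once, so the compounds shown do not say which of these matters; a plain naphthyl group or a methoxyphenyl group on this carbon would begin to separate them. As far as these compounds go, it also remains open how an amine or a carboxylic acid on the aromatic ring at this carbon would read, and, with a single concentration tested, how the compounds compare in potency.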